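Swapping Phenethyl for 4-Fluorophenyl on the Sulfur Chain

The source may hold more compounds than are shown below. What is called first, only, known or untested is meant among the compounds shown, and "the series" means these compounds.

Compound 3 `Cc1cc(N2CC[C@@H](C)[C@@H](N(C)c3ncnc4[nH]ccc34)C2)n2nc(SCCCc3ccccc3)nc2n1` belongs to a set of three compounds sharing one core and differing only on a saturated chain carbon bound to a sulfur. In a toxicity assay on GES1 cells (Homo sapiens) for inhibition, read by MTT assay, with a stated time of 72 h (a lower number here means a stronger inhibitor, a higher number a weaker inhibitor), compound 3 gives > 100000 nM, a limit of the assay rather than a number. Compound 1 `C=CCSc1nc2nc(C)cc(N3CC[C@@H](C)[C@@H](N(C)c4ncnc5[nH]ccc45)C3)n2n1` gives > 100000 nM, also a limit. Compound 2 `Cc1cc(N2CC[C@@H](C)[C@@H](N(C)c3ncnc4[nH]ccc34)C2)n2nc(SCc3ccccc3Br)nc2n1` gives > 100000 nM, again a limit. The steps a step that the two limits leave unreadable from compound 1 to compound 2, a step that the two limits leave unreadable from compound 1 to compound 3 and a step that the two limits leave unreadable from compound 2 to compound 3 are therefore unreadable in size, since the limit of > 100000 nM in this assay, at which 3 of the 3 values shown sit, marks where all three values sit. Compound 4 `Cc1cc(N2CC[C@@H](C)[C@@H](N(C)c3ncnc4[nH]ccc34)C2)n2nc(SCc3ccc(F)cc3)nc2n1` differs from compound 3 by 4-fluorophenyl in place of phenethyl on a saturated chain carbon bound to a sulfur. Among the compounds with values here, no measured step reads a size for such a change, so no movement beyond the scatter is expected in this assay. Compound 4 is expected to give 100000 nM (range 30000 nM to 300000 nM). That expectation corresponds to a number no higher from compound 3 to compound 4 (the limit leaves the size open).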

Compound 4, half-maximal inhibitory concentration: 12300 nM
Compound 4: the middle estimate sits 8.1-fold (0.91 log units) above what was measured; measured number outside the range, below it.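

In this assay compound 4 is the only one of the set that reads as a number, so a change on a saturated chain carbon bound to a sulfur now registers at all. Putting 4-fluorophenyl there gives an at least 8.1-fold lower number from compound 3 to compound 4 (0.91 log units; beyond the scatter) and an at least 8.1-fold lower number from compound 2 to compound 4 (0.91 log units; beyond the scatter) and an at least 8.1-fold lower number from compound 1 to compound 4 (0.91 log units; beyond the scatter) with each size a minimum, while the steps among the other three cannot be read. Those three share one limit: the limit of > 100000 nM in this assay, at which 3 of the 4 values shown sit.

Compound 4 differs from compound 3 in both chain length and fluorine, and the compounds shown do not separate the two. Nor do they tell how an amine or a carboxylic acid on this chain would read.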